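Azido for methoxymethoxy on a shared core

The source may report more compounds than this note shows. Statements on the series, on what has been measured and on what is new or still open speak of the compounds shown alone.

In a functional assay on SMMC-7721 cells (Homo sapiens) for antiproliferative activity, read by MTT assay, with a stated time of 48 h (a lower number here means a stronger inhibitor, a higher number a weaker inhibitor), compound 3 `COCOC/C1=C/C[C@](C)(CCC=C(C)C)/C=C/[C@@H](OC(=O)C=C(C)C)[C@](C)(O)/C=C/C1=O` gives 3250 nM as its result. Compound 2 `CC(C)=CCC[C@]1(C)/C=C/[C@@H](OC(=O)C=C(C)C)[C@](C)(O)/C=C/C(=O)/C(CN2CCN(C)CC2)=C\C1` gives 2940 nM as a matching result, and a 1.1-fold higher number from compound 2 to compound 3 (0.04 log units; within the scatter) lies within the scatter. Compound 1 `CC(C)=CCC[C@]1(C)/C=C/[C@@H](OC(=O)C=C(C)C)[C@](C)(O)/C=C/C(=O)/C(CN2CCCC2)=C\C1` is far stronger at 140 nM with a 23-fold higher number from compound 1 to compound 3 (1.37 log units; beyond the scatter) and a 21-fold higher number from compound 1 to compound 2 (1.32 log units; beyond the scatter) as large steps. Compound 4 `CC(C)=CCC[C@]1(C)/C=C/[C@@H](OC(=O)C=C(C)C)[C@](C)(O)/C=C/C(=O)/C(CN=[N+]=[N-])=C\C1` has azido in place of methoxymethoxy on a saturated chain carbon bound to a double-bonded ring carbon. All these steps change the group at this place, and their sizes run from nothing beyond the scatter to large. Going by the values given here, no measured compound carries azido. The expectation therefore stays near compound 3 at 3250 nM with a modest lean toward a lower number in this assay overall. The expected step is a 1.8-fold lower number from compound 3 to compound 4 (0.26 log units; within the scatter) in size. Compound 4 is estimated at 1800 nM within a range of 400 nM to 7000 nM for now.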

Compound 4, half-maximal inhibitory concentration: 3080 nM
Compound 4: middle estimate off by 1.7-fold (0.23 log units), on the low side, and the stated range covers the measured number.
By their numbers in this assay, from the lowest: compound 1; then compounds 2, 4 and 3 (each within the scatter of the next).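

In this assay, azido reads the same as methoxymethoxy at this place, since a 1.1-fold lower number from compound 3 to compound 4 (0.02 log units; within the scatter) stays inside the scatter, and a 1.0-fold higher number from compound 2 to compound 4 (0.02 log units; within the scatter) does too. Three different groups, azido, methoxymethoxy and 4-methylpiperazin-1-yl, therefore read alike, while pyrrolidin-1-yl stands apart, with a 22-fold higher number from compound 1 to compound 4 (1.34 log units; beyond the scatter) as a large step. No measured evidence here explains this split.

The compounds shown leave open how piperidin-1-yl, morpholin-4-yl or a plain dimethylamino group would read at this place. Whether compound 1 is a lone case among amines therefore stays unsettled.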